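Swapping Fluoro for Cyclopropyl on a Shared Core

The source may hold more compounds than are shown below. What is called first, only, known or untested is meant among the compounds shown, and "the series" means these compounds.

Of the compounds shown here, three built on one shared core have been measured in an ADME assay on microsomes from liver (Mus musculus) for metabolic stability, read by LC-MS, using NADPH, with a stated time of 10 min, tested at 0.5 uM; a higher number here means that more of the compound is left, a lower number that less of the compound is left. Compound 1 `CC(=O)Nc1cc(-c2ccc(OC[C@@](C)(N)CC(C)C)c(F)c2)ccn1` gives 70% in this assay. Compound 2 `COC(=O)Nc1cc(-c2ccc(OC[C@@](C)(N)CC(C)C)c(C)c2)ccn1` gives 75% in this assay. Compound 3 `COC(=O)Nc1cc(-c2ccc(OC[C@@](C)(N)CC(C)C)c(F)c2)ccn1` gives 71% in this assay. Compound 3 sits close to both of the others: the step of a number 1 percentage points higher from compound 1 to compound 3 (within the scatter) and the step of a number 4 percentage points lower from compound 2 to compound 3 (within the scatter) are both within the scatter, so nothing separates the three numbers beyond the noise of repeated measurement.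

Compound 4 `COC(=O)Nc1cc(-c2ccc(OC[C@@](C)(N)CC(C)C)c(C3CC3)c2)ccn1` differs from compound 3 in one place: cyclopropyl in place of fluoro on an aromatic carbon. Among the measured compounds shown here, no measured pair shows this exact exchange. The nearest measured step is a number 4 percentage points lower from compound 2 to compound 3 (within the scatter), where fluoro and methyl on an aromatic carbon gave numbers within the scatter; the step of a number 1 percentage points higher from compound 1 to compound 3 (within the scatter) concerns a different part of the molecule and carries less weight here. Because the step of a number 4 percentage points lower from compound 2 to compound 3 (within the scatter) was within the scatter, compound 4 is expected to stay near compound 3, with an expected step of a number 5 percentage points lower from compound 3 to compound 4 (within the scatter) that does not go beyond the scatter. Compound 4 is estimated at 66%, with a range from 48% to 80%.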

Compound 4, percent of the compound remaining: 33%
Estimate against measurement, compound 4: 33 percentage points above, and the stated range ends above it.
By their numbers in this assay, from the lowest: compound 4; then compounds 1, 3 and 2 (each within the scatter of the next).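

At this aromatic carbon, ortho to the (2-amino-2,4-dimethylpentyl)oxy group, fluoro and methyl had given numbers within the scatter, so the position looked as if it made little difference in this assay. Cyclopropyl changes that picture, with a number 38 percentage points lower from compound 3 to compound 4 (beyond the scatter) when it replaces fluoro and a number 42 percentage points lower from compound 2 to compound 4 (beyond the scatter) when it replaces methyl, so this position is not indifferent to every group placed there. Nothing available here explains why the three-membered ring behaves so differently from the two smaller groups.

As far as these compounds go, whether an ethyl or an isopropyl group at this carbon would stay close to methyl or fall with cyclopropyl remains open. Also open, from the compounds shown here alone, is whether cyclopropyl would give a similar result alongside the methyl on the carbonyl carbon of compound 1.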